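Swapping chloro for trifluoromethyl on a shared core

This account rests on a few compounds, and the source may have more. Where it says the series, first, only, none or still open, it means among the compounds named here.

Three compounds share one core and differ only in the group on the outer benzene ring. Compound 1 `COc1ccc2cc(C(C)c3nnc4n3N=C(c3ccc(F)cc3)CS4)ccc2c1` carries fluoro there; in a functional assay on Huh-7 cells (Homo sapiens) for inhibition, read by sulforhodamine B assay, with a stated time of 72 h (a higher number here means a weaker inhibitor, a lower number a stronger inhibitor), compound 1 gives 7000 nM. Compound 2 `COc1ccc(C2=Nn3c(nnc3C(C)c3ccc4cc(OC)ccc4c3)SC2)cc1` carries methoxy, and in this assay compound 2 gives 8500 nM. Compound 3 `COc1ccc2cc(C(C)c3nnc4n3N=C(c3ccc(Cl)cc3)CS4)ccc2c1` carries chloro; in this assay compound 3 gives 5600 nM, the lowest of the three numbers, yet the gaps to the other two are within the scatter, so the three cannot be ranked. The steps of a 1.3-fold lower number from compound 1 to compound 3 (0.10 log units; within the scatter) and a 1.5-fold lower number from compound 2 to compound 3 (0.18 log units; within the scatter) were both small, as was a 1.2-fold higher number from compound 1 to compound 2 (0.08 log units; within the scatter).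

Compound 4 `COc1ccc2cc(C(C)c3nnc4n3N=C(c3ccc(C(F)(F)F)cc3)CS4)ccc2c1` is the next member: trifluoromethyl in place of chloro on an aromatic carbon. Every change so far at this position, whether to a halogen or to methoxy, left the number essentially where it was, so the expectation is that this exchange also produces no step beyond the scatter. For compound 4 the expected step is no change at the digits printed from compound 3 to compound 4 (within the scatter), and in this assay compound 4 is estimated at 5600 nM, with a range from 2500 nM to 12500 nM.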

Compound 4, half-maximal inhibitory concentration: 14800 nM
For compound 4 the middle estimate is 2.6-fold (0.42 log units) below the measured one, and the stated range ends below it.
By their numbers in this assay, from the lowest: compounds 3, 1, 2 and 4 (each within the scatter of the next, the first and the last beyond it).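

Within the data shown here, this position does respond to what sits on it: in this assay, the change from 4-chlorophenyl to 4-(trifluoromethyl)phenyl gives a 2.6-fold higher number from compound 3 to compound 4 (0.42 log units; beyond the scatter) and is the first step here to leave the scatter, while a 2.1-fold higher number from compound 1 to compound 4 (0.33 log units; beyond the scatter) also lies beyond it, and both steps are modest. By contrast, a 1.7-fold higher number from compound 2 to compound 4 (0.24 log units; within the scatter) stays within the scatter, so trifluoromethyl separates from chloro and fluoro but not from methoxy, and the series has no single clear end-to-end order. No measured evidence in hand explains the difference between trifluoromethyl and the two halogens.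

The compounds shown leave open whether a very different group on this aromatic carbon, such as an amine or a carboxylic acid, would move the number further in either direction, or whether any group here can bring it well below the values seen so far. They also leave open whether trifluoromethyl in place of chloro would give a similar step on a different core, since this exchange is seen only once, on the shared core of these four compounds.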